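From Methyl to Dichloro on the Sulfonyl Aryl Ring

The source may hold more compounds than are shown below. What is called first, only, known or untested is meant among the compounds shown, and "the series" means these compounds.

Three compounds have so far been measured in an assay on cells for inhibition of HSP60/HSP10 (Homo sapiens), with a stated time of 60 min; a lower number here means a stronger inhibitor, a higher number a weaker inhibitor:

Compound 1 `O=S(=O)(Nc1ccc2oc(-c3ccccc3)nc2c1)c1cccc(C(F)(F)F)c1`: > 100000 nM
Compound 2 `Cc1ccc(S(=O)(=O)Nc2ccc(-c3nc4ccccc4o3)cc2)cc1`: > 100000 nM
Compound 3 `O=S(=O)(Nc1ccc(-c2nc3ccccc3o2)cc1)c1ccc(C(F)(F)F)cc1`: 50000 nM

Compound 2 stands at the ceiling of the range: its value is a limit of the assay, not a number. The same holds for compound 1, whose value is also a limit. Going by the values given here, only compound 3 returns a number, and the one measured step on the sulfonyl aryl ring, an at least 2.0-fold lower number from compound 2 to compound 3 (0.30 log units; that floor lies within the scatter), has a floor that lies within the usual scatter; the data show two of three readings sitting at the limit of > 100000 nM in this assay, at which 2 of the 3 values shown sit, so little can be resolved here.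

Compound 4 `O=S(=O)(Nc1ccc(-c2nc3ccccc3o2)cc1)c1ccc(Cl)c(Cl)c1` differs from compound 2 by 3,4-dichlorophenyl in place of 4-methylphenyl on a sulfonyl sulfur. Among the compounds with values here, no measured step carries a dichlorophenyl, so the only step that bears on it is the one from compound 2 to compound 3, which touched the same ring and produced at most a small move. A change of comparable size is therefore expected, downward if anything, with a fair chance that the assay once more reports only a limit.

The step is estimated as an at least 1.6-fold lower number from compound 2 to compound 4 (0.22 log units; that floor lies within the scatter). For compound 4 the expected value in this assay is 60000 nM, within a range from 15000 nM to 300000 nM.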

Compound 4, half-maximal inhibitory concentration: 25000 nM
Compound 4: the middle estimate sits 2.4-fold (0.38 log units) above what was measured; measured number inside the range.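

On the sulfonyl aryl ring, 3,4-dichlorophenyl in place of 4-methylphenyl on a sulfonyl sulfur brings an at least 4.0-fold lower number from compound 2 to compound 4 (0.60 log units; beyond the scatter) in this assay, so this position now shows a step that clears the scatter, whereas the floor of the earlier step, an at least 2.0-fold lower number from compound 2 to compound 3 (0.30 log units; that floor lies within the scatter), did not. Compound 3 reads 50000 nM and compound 4 reads 25000 nM; these are the only two numbers shown, and no order between them is claimed. The value of compound 2 is a limit of the assay, so the new step is only a floor and its true size cannot be read: the limit of > 100000 nM in this assay, at which 2 of the 4 values shown sit.

Whether the step needs both chlorines stays open, since a phenyl with a single chlorine is not among the compounds shown. Also open, as far as these compounds go, is how a methoxy, a nitrile or a carboxylic acid on this ring would read, and whether 3,4-dichlorophenyl would bring a similar step on the core of compound 1.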